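A few compounds are considered here, and "the series" means these few. Any claim that something is new, unique, unknown or untested is made for them only; others in the source may bear on it.

Working notes on the series.

Of the compounds shown here, three have been measured in a functional assay on MDA-MB-231 cells (Homo sapiens) for antiproliferative activity, read by MTT assay, with a stated time of 48 h; a lower number here means a stronger inhibitor, a higher number a weaker inhibitor. Compound 1 `COc1cc(/C=N/c2c(C#N)ncn2-c2ccc(F)cc2)cc(OC)c1OC` gives 18700 nM. Compound 2 `N#Cc1ncn(-c2ccc(F)cc2)c1/N=C/c1ccc([N+](=O)[O-])cc1` gives 13400 nM; the difference between the cores of compound 2 and compound 1 is not broken down here. Compound 3 `COc1cc(/C=N/c2c(C#N)ncn2Cc2ccc(F)cc2)cc(OC)c1OC` gives 2870 nM.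

Going by the values given here, the one counted step among the measured compounds is a 6.5-fold lower number from compound 1 to compound 3 (0.81 log units; beyond the scatter), described as 4-fluorobenzyl in place of 4-fluorophenyl on an aromatic nitrogen. Compound 2 stands near compound 1 in this assay, the two values lying within the scatter of each other, while compound 3 sits well apart from both.

Compound 4 `N#Cc1ncn(Cc2ccc(F)cc2)c1/N=C/c1ccc([N+](=O)[O-])cc1` has not yet been measured in this assay. It differs from compound 2 by 4-fluorobenzyl in place of 4-fluorophenyl on an aromatic nitrogen. The place description for this change is the same word for word as that for the change from compound 1 to compound 3, so this is the same change made on the second core. The expectation therefore rests on a single precedent, the step from compound 1 to compound 3, and on the starting value of compound 2.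

For compound 4 a step of about a 5.6-fold lower number from compound 2 to compound 4 (0.75 log units; beyond the scatter) is expected, close to the earlier one, because the earlier step of a 6.5-fold lower number from compound 1 to compound 3 (0.81 log units; beyond the scatter) lies beyond the scatter. On that basis compound 4 is estimated at 2400 nM in this assay, with a plausible range from 900 nM to 7000 nM.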

Compound 4, half-maximal inhibitory concentration: 3440 nM
Compound 4: the middle estimate sits 1.4-fold (0.16 log units) below what was measured, within the range that was stated.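

In this assay, 4-fluorobenzyl in place of 4-fluorophenyl on an aromatic nitrogen gives a 3.9-fold lower number from compound 2 to compound 4 (0.59 log units; beyond the scatter), and the change carries over to the second core in the same direction and with a size that cannot be told apart from the first: the same change on two cores in this assay, a 6.5-fold lower number (0.81 log units; beyond the scatter) from compound 1 to compound 3 and a 3.9-fold lower number (0.59 log units; beyond the scatter) from compound 2 to compound 4, 1.7-fold (0.22 log units) apart, within the scatter of two such steps

Within these four compounds, the 4-fluorobenzyl member of each pair therefore gives the lower number, and no pair goes against this. This does not amount to a general rule: the precedent covers only the core of compound 1 and the core of compound 2, a gap within the scatter does not prove that the two steps are identical, and nothing here explains why the change lowers the number.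

The compounds shown leave open whether a longer chain on that aromatic nitrogen, such as 2-(4-fluorophenyl)ethyl, would continue the trend, and whether the fluorine is needed at all, as an unsubstituted benzyl would show. They also leave open whether the step survives on a core carrying an amine or a carboxylic acid in place of the nitro group of compound 4.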